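Swapping Methoxy for Trifluoromethoxy on Compound 1

The source may report more compounds than this note shows. Statements on the series, on what has been measured and on what is new or still open speak of the compounds shown alone.

Within the data shown here, in a functional assay on HCT-116 cells (Homo sapiens) for inhibition (on this read-out lower numbers stand for stronger inhibition and higher numbers for weaker inhibition), compound 1 `COc1cccc(/C=C\c2ccc3ccccc3c2)c1` gives 1920 nM, the higher of the two numbers measured so far. Compound 2 `COc1cc(/C=C\c2ccc3ccccc3c2)ccc1F`, which carries fluoro in place of hydrogen on an aromatic carbon, gives 450 nM. Compound 3 `FC(F)(F)Oc1cccc(/C=C\c2ccc3ccccc3c2)c1` keeps the core of compound 1 and alters one group: trifluoromethyl in place of methyl on an oxygen on an aromatic ring, or methoxy to trifluoromethoxy. Among the measured compounds shown here, only one measured step is available, and it does not touch the group on this oxygen, so a 4.3-fold lower number from compound 1 to compound 2 (0.63 log units; beyond the scatter) serves as a rough guide to size and gives no direction. A step of that modest size or smaller is therefore expected in this assay, with no firm lean either way. The expected change is a 1.3-fold lower number from compound 1 to compound 3 (0.11 log units; within the scatter). For compound 3 the estimated value is 1500 nM, with an expected range of 500 nM to 4500 nM.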

Compound 3, half-maximal inhibitory concentration: 3500 nM
Beside the measured number, compound 3's estimate is 2.3-fold (0.37 log units) below it; the range from low to high includes it.
By their numbers in this assay, from the lowest: compound 2; then compounds 1 and 3 (each within the scatter of the next).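

In this assay, trifluoromethyl in place of methyl on this oxygen gives a 1.8-fold higher number from compound 1 to compound 3 (0.26 log units; within the scatter) as the step, so compound 1 and compound 3 cannot be told apart on this read-out. Among these compounds, this is the first view of a change at the group on the oxygen itself, since the earlier step, a 4.3-fold lower number from compound 1 to compound 2 (0.63 log units; beyond the scatter) as its size, concerned an aromatic carbon, and it shows that going from 1 heavy atom to 4 at this place leaves the number within the usual scatter. Nothing measured on these groups bears on this result.

Still open, as far as these compounds go, is how far this place can be altered, for instance with a hydroxyl, an amine or a longer chain such as butoxy on the ring. From the compounds shown here alone, it is also open whether the fluoro change seen in compound 2 would have the same effect alongside trifluoromethoxy.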